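Adding Trifluoromethyl to Compound 3

The source may hold more compounds than are shown below. What is called first, only, known or untested is meant among the compounds shown, and "the series" means these compounds.

For the measured compounds named here, in a functional assay on A20 cells (Mus musculus) for inhibition, with stated times of 1 h, 16 h and 24 h (on this read-out lower numbers stand for stronger inhibition and higher numbers for weaker inhibition), compound 3 (`N#CCNC(=O)[C@@H]1CN(S(=O)(=O)c2ccccc2)C[C@H]1C(=O)N1CCOCC1`) gives 4240 nM, the highest of the three numbers so far and so the weakest inhibition. Compound 2 (`N#CC1(NC(=O)[C@@H]2C[C@@H](S(=O)(=O)c3ccccc3)C[C@H]2C(=O)Nc2ccc(F)cc2)CC1`) gives 391 nM, and compound 1 (`N#CCNC(=O)[C@@H]1C[C@@H](S(=O)(=O)c2ccccc2C(F)(F)F)C[C@H]1C(=O)N1CCOCC1`) gives 2 nM; both gaps to compound 3 lie beyond the scatter. Compound 4 (`N#CCNC(=O)[C@@H]1CN(S(=O)(=O)c2ccccc2C(F)(F)F)C[C@H]1C(=O)N1CCOCC1`) has trifluoromethyl in place of hydrogen on an aromatic carbon of compound 3: trifluoromethyl in place of hydrogen on an aromatic carbon. Going by the values given here, no measured pair shows this change alone. Compound 1, at 2 nM, carries the same 2-(trifluoromethyl)phenyl group on a different core, which suggests a large move toward stronger inhibition, though probably not the whole gap. In this assay the expected step is a 42-fold lower number from compound 3 to compound 4 (1.63 log units; beyond the scatter). For compound 4 the estimated value is 100 nM, within an expected range of 15 nM to 700 nM.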

Compound 4, half-maximal inhibitory concentration: 118 nM
Compound 4: the middle estimate sits 1.2-fold (0.07 log units) below what was measured; measured number inside the range.
By their numbers in this assay, from the lowest: compound 1; then compound 4; then compound 2; then compound 3.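

In this assay, for the compounds shown here, the swap from phenyl to 2-(trifluoromethyl)phenyl, with nothing else changed, gives a 36-fold lower number from compound 3 to compound 4 (1.56 log units; beyond the scatter) and is the first direct reading of this change. It shows that this aromatic carbon is a place where a single substitution can strongly shift the read-out toward stronger inhibition. Nothing at hand explains the size of this step. Going by these compounds, whether a methyl group or a single chlorine atom on the same carbon would give a similar step remains open. So does whether trifluoromethyl would do the same on another core.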